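The compounds below may be only part of what the source reports. "The series", "measured", "known", "first", "only" and "open" are said of these compounds alone.

In an assay on isolated protein for inhibition of DNA topoisomerase 1 (Homo sapiens), with a stated time of 30 min, tested at 100 uM (on this read-out higher numbers stand for a stronger effect at the one concentration tested and lower numbers for a weaker effect), three compounds sharing one core have been measured. Compound 1 `Oc1ccc(-c2cc(-c3ccccn3)nc(-c3ccccc3Cl)c2)cc1` gives 5.2%, compound 2 `Oc1ccc(-c2cc(-c3ccccc3)nc(-c3ccccc3Cl)c2)cc1` gives 13.6%, and compound 3 `Oc1ccc(-c2cc(-c3cccs3)nc(-c3ccccc3Cl)c2)cc1` gives 2.2%. Compound 3 thus stands at the low end of the three numbers, although its gap to compound 1, a number 3 percentage points lower from compound 1 to compound 3 (within the scatter), falls within the scatter, while its gap to compound 2, a number 11.4 percentage points lower from compound 2 to compound 3 (beyond the scatter), is modest but beyond it. The remaining measured step, a number 8.4 percentage points higher from compound 1 to compound 2 (within the scatter), is also within the scatter.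

Compound 4 `Oc1ccc(-c2cc(-c3ccco3)nc(-c3ccccc3Cl)c2)cc1` has not yet been measured in this assay. It differs from compound 3 in one place: furan-2-yl in place of thiophen-2-yl on an aromatic carbon. Going by the values given here, the steps that bear on this position are those exchanging the group on that same aromatic carbon, from pyridin-2-yl to thiophen-2-yl and from phenyl to thiophen-2-yl, and both were small, one within and one just beyond the scatter. A swap of thiophen-2-yl for furan-2-yl is expected to be no larger, and the value of compound 4 in this assay is therefore expected to sit near that of compound 3, with no step beyond the scatter, a number 1.8 percentage points higher from compound 3 to compound 4 (within the scatter). Compound 4 is estimated at 4%, in a range from 0% to 13%.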

Compound 4, a percentage reported as inhibition, at one concentration (the size of the read-out at that concentration, not a potency): 3.9%
For compound 4 the middle estimate is 0.1 percentage points above the measured one; measured number inside the range.
By their numbers in this assay, from the lowest: compounds 3, 4, 1 and 2 (each within the scatter of the next, the first and the last beyond it).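

In this assay, oxygen in place of sulfur in the five-membered aromatic ring on this carbon gave a step within the scatter (a number 1.7 percentage points higher from compound 3 to compound 4 (within the scatter)), so this exchange of the hetero atom shows no effect that can be told apart on this read-out. Going by these compounds alone, compound 4 also lies within the scatter of both compounds with a six-membered ring at this place (a number 1.3 percentage points lower from compound 1 to compound 4 (within the scatter); a number 9.7 percentage points lower from compound 2 to compound 4 (within the scatter)), whereas the step from phenyl to thiophen-2-yl lay beyond it (a number 11.4 percentage points lower from compound 2 to compound 3 (beyond the scatter)), so that one step beyond the scatter has no counterpart with furan-2-yl, though the two steps from phenyl are close in size. Nothing available on these compounds accounts for these numbers.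

What an amine, a carboxylic acid or a longer alkyl chain on this same aromatic carbon would give remains open, since all four groups shown here are single aromatic rings. Also open, as far as these compounds go, is whether replacing the 2-chlorophenyl group or the 4-hydroxyphenyl group would lift the numbers of this series, which here rest on one concentration only.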